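Replacing Trifluoromethyl with Difluoromethyl in a Clearance Series

A few compounds are considered here, and "the series" means these few. Any claim that something is new, unique, unknown or untested is made for them only; others in the source may bear on it.

Of the compounds shown here, three have been measured in an ADME assay on microsomes from liver (Homo sapiens) for metabolic stability (on this read-out lower numbers stand for slow clearance and higher numbers for fast clearance), so far.

Compound 1 `O=C(Nc1ccc(Cl)cc1)C(=O)N1CCC(c2ccnc3ccc(F)cc23)CC1` gives 9 mL.min-1.g-1
Compound 2 `N#Cc1ccc(NC(=O)C(=O)N2CCC(c3ccnc4ccc(F)cc34)CC2)cc1` gives 11 mL.min-1.g-1
Compound 3 `O=C(Nc1ccc(C(F)(F)F)cc1)C(=O)N1CCC(c2ccnc3ccc(F)cc23)CC1` gives 5.5 mL.min-1.g-1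

Compound 3 (5.5 mL.min-1.g-1) cannot be separated from compound 1 or compound 2 on these numbers, as its steps to both lie within the scatter. The next compound to be measured is compound 4 `O=C(Nc1ccc(C(F)F)cc1)C(=O)N1CCC(c2ccnc3ccc(F)cc23)CC1` and its difference from compound 3 is hydrogen in place of fluoro on a saturated chain carbon bound to an aromatic carbon and two fluorine atoms which amounts to hydrogen in place of fluoro on a saturated chain carbon bound to an aromatic carbon and two fluorine atoms, or trifluoromethyl to difluoromethyl.

Going by the values given here, no measured step makes this exact replacement. The closest evidence comes from the exchanges among chloro, cyano and trifluoromethyl on an aromatic carbon. These are a 1.2-fold higher number from compound 1 to compound 2 (0.09 log units; within the scatter) along with a 1.6-fold lower number from compound 1 to compound 3 (0.21 log units; within the scatter) and a 2.0-fold lower number from compound 2 to compound 3 (0.30 log units; within the scatter) and all of them stay within the scatter. A change confined to a single fluoro therefore offers no ground for expecting a large shift. The expected step is small and upward, a 1.3-fold higher number from compound 3 to compound 4 (0.10 log units; within the scatter) and so not beyond the scatter. In this assay compound 4 is estimated at 7 mL.min-1.g-1 (range 3.5 mL.min-1.g-1 to 13 mL.min-1.g-1).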

Compound 4, intrinsic clearance in microsomes: 17 mL.min-1.g-1
Compound 4: the middle estimate sits 2.4-fold (0.39 log units) below what was measured; measured number above the stated range.
By their numbers in this assay, from the lowest: compounds 3, 1, 2 and 4 (each within the scatter of the next, the first and the last beyond it).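

Taking a single fluoro out of the trifluoromethyl group gives the first step at this aromatic substituent to pass the scatter in this assay (a 3.1-fold higher number from compound 3 to compound 4 (0.49 log units; beyond the scatter)), whereas the exchanges among chloro, cyano and trifluoromethyl had all stayed within it. Difluoromethyl is not set apart from the other two groups, however: its steps from cyano (a 1.5-fold higher number from compound 2 to compound 4 (0.19 log units; within the scatter)) and from chloro (a 1.9-fold higher number from compound 1 to compound 4 (0.28 log units; within the scatter)) remain within the scatter, so among these four compounds only the pair of compound 3 and compound 4 can be told apart, and the change of one fluoro to hydrogen matters here as a difference from trifluoromethyl alone. Nothing available offers an account of why this step is as large as it is.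

The compounds shown leave open whether a monofluoromethyl or a plain methyl group on the same aromatic carbon would read closer to compound 3 or to compound 4 in this assay. They also leave open whether the trifluoromethyl to difluoromethyl step would be of similar size on a core other than the one shared here.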